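This account rests on a few compounds, and the source may have more. Where it says the series, first, only, none or still open, it means among the compounds named here.

Compound 1 `ClCc1ccc(Cn2cnc3nc(Cl)nc(Cl)c32)cc1` was tested in a functional assay on NCI-H460 cells (Homo sapiens) for cytotoxicity, read by sulforhodamine B assay, with a stated time of 48 h (on this read-out higher numbers stand for weaker inhibition of growth and lower numbers for stronger inhibition of growth), where compound 1 gives 35500 nM. For the measured compounds named here, of the two numbers in hand this is the higher one; the only other compound, compound 2 `ClCc1ccccc1Cn1cnc2nc(Cl)nc(Cl)c21`, gives 5880 nM in this assay, a lower number that lies beyond the scatter of the method. No step is listed between these two, so only their values are noted.

Compound 3 `ClCc1ccc(Cn2cnc3ncnc(Cl)c32)cc1` has not yet been measured in this assay. Compared with compound 1, compound 3 shows the following change: hydrogen in place of chloro on an aromatic carbon. Going by the values given here, with no measured pair to lean on, the step is expected to be small, most likely towards a somewhat higher number and possibly within the scatter. The step from compound 1 to compound 3 is therefore estimated as a 1.4-fold higher number from compound 1 to compound 3 (0.15 log units; within the scatter). On this basis compound 3 is expected to give 50000 nM in this assay, within a range from 18000 nM to 140000 nM.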

Compound 3, concentration for total growth inhibition: 4260 nM
For compound 3 the middle estimate is 12-fold (1.07 log units) above the measured one, outside the stated range (below it).
By their numbers in this assay, from the lowest: compounds 3 and 2 (each within the scatter of the next); then compound 1.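

In this assay, hydrogen in place of chloro on the aromatic carbon between two ring nitrogen atoms gives an 8.3-fold lower number from compound 1 to compound 3 (0.92 log units; beyond the scatter) and so moves the read-out towards stronger inhibition of growth. For the compounds shown here, this is the first single-place comparison, and it shows that this position is not neutral in this assay and that the chloro group on this carbon is not required for growth inhibition. No measurement at hand explains the change in the read-out.

On these data alone, it remains open how an amine, a methoxy group or a methyl group on the same carbon would compare with hydrogen and chloro. As far as these compounds go, it is also open whether hydrogen in place of chloro at this position would give a step of similar size on compound 2 .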